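Adding an ethyl to the acid oxygen of compound 3

This account rests on a few compounds, and the source may have more. Where it says the series, first, only, none or still open, it means among the compounds named here.

Compound 1 `CCOC(=O)c1c(C)oc2ncnc(Nc3ccccc3)c12` gives 851000 nM in a functional assay on MCF7 cells (Homo sapiens) for cytotoxicity, read by MTT assay, with a stated time of 72 h; on this read-out lower numbers stand for stronger inhibition and higher numbers for weaker inhibition.
Compound 2 `Cc1oc2ncnc(Nc3ccccc3)c2c1C(=O)O` gives 246000 nM in this assay.
Compound 3 `Cc1oc2ncnc(Nc3cccc(Cl)c3)c2c1C(=O)O` gives 57500 nM in this assay.

Compound 1 and compound 2 differ in one place: ethyl in place of hydrogen on an oxygen next to a carbonyl group. That change made the step of a 3.5-fold higher number from compound 2 to compound 1 (0.54 log units; beyond the scatter), a weakening. Compound 3 differs from compound 2 in another place: chloro in place of hydrogen on an aromatic carbon. That change made the step of a 4.3-fold lower number from compound 2 to compound 3 (0.63 log units; beyond the scatter), and it leaves compound 3 with the lowest number of the three.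

Compound 4 `CCOC(=O)c1c(C)oc2ncnc(Nc3cccc(Cl)c3)c12` has not yet been measured. It relates to compound 3 as compound 1 relates to compound 2: ethyl in place of hydrogen on an oxygen next to a carbonyl group. The place of the change is the same in both pairs, so the two changes are the same, though the two cores differ as described.

If the change behaves on the core of compound 3 as it did between compound 2 and compound 1, the step from compound 3 to compound 4 is expected to be a 3.5-fold higher number from compound 3 to compound 4 (0.54 log units; beyond the scatter) in this assay, resting on a 3.5-fold higher number from compound 2 to compound 1 (0.54 log units; beyond the scatter). On that basis compound 4 is estimated at 200000 nM, likely between 80000 nM and 500000 nM.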

Compound 4, half-maximal inhibitory concentration: > 1000000 nM
Compound 4: no number, only a limit; the forecaster's own chance of this, stated with the estimate: 10%; middle value at least 5.0-fold (0.69 log units) away from the limit.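

Compound 4 gives > 1000000 nM in this assay, which is a limit of the assay and not a number. Even so, ethyl in place of hydrogen on the acid oxygen weakens the result on the chlorinated core, an at least 17-fold higher number from compound 3 to compound 4 (1.24 log units; beyond the scatter), by more than it did on the core without chloro, so this change does not carry over at a single size: the same change on two cores in this assay, a 3.5-fold higher number (0.54 log units; beyond the scatter) from compound 2 to compound 1 and an at least 17-fold higher number (1.24 log units; beyond the scatter) from compound 3 to compound 4, at least 5.0-fold (0.70 log units) apart, beyond the scatter of two such steps The chloro change does not carry over either, since it lowered the number on the acid but on the ethyl ester gives an at least 1.1-fold higher number from compound 1 to compound 4 (0.07 log units; that floor lies within the scatter), though only floors are known here, not the true sizes of these steps or any cause: the same change on two cores in this assay, a 4.3-fold lower number (0.63 log units; beyond the scatter) from compound 2 to compound 3 and an at least 1.1-fold higher number (0.07 log units; that floor lies within the scatter) from compound 1 to compound 4, at least 5.0-fold (0.70 log units) apart, beyond the scatter of two such steps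

These compounds leave open whether a longer chain on the same oxygen, such as propyl, or an amide in place of the ester, would behave like the ethyl group. On these data alone, it also remains open whether fluoro or methoxy in place of chloro would show the same dependence on the acid or ester.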